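A few compounds are considered here, and "the series" means these few. Any claim that something is new, unique, unknown or untested is made for them only; others in the source may bear on it.

Compound 1 `CCCc1nc2ncccc2n1Cc1cc(Cl)c(O)c(Cl)c1` and compound 2 `Oc1c(Cl)cc(Cn2c(C3CC3)nc3ncccc32)cc1Cl` share one core. In a functional assay (aorta) with Oryctolagus cuniculus as the target (a lower number here means tighter binding, a higher number weaker binding), compound 1 gives 794 nM, and compound 2 gives 631 nM. The change between them is cyclopropyl in place of propyl on an aromatic carbon, and it made a 1.3-fold lower number from compound 1 to compound 2 (0.10 log units; within the scatter). Compound 3 `CCCc1nc2c(C)ccnc2n1Cc1cc(Cl)c(O)c(Cl)c1` carries a different core; the difference between the two cores is not broken down here. In this assay compound 3 gives 1.26 nM, the lowest of the three numbers and beyond the scatter from both others. Compound 4 `Cc1ccnc2c1nc(C1CC1)n2Cc1cc(Cl)c(O)c(Cl)c1` is not yet measured. It differs from compound 3 by cyclopropyl in place of propyl on an aromatic carbon, the same change as between compound 1 and compound 2, at a place described in the same words. Because a 1.3-fold lower number from compound 1 to compound 2 (0.10 log units; within the scatter) stayed within the scatter, the expected step is a 1.0-fold higher number from compound 3 to compound 4 (0.01 log units; within the scatter). For compound 4 in this assay the estimate is 1.3 nM, with a range from 0.5 nM to 4 nM.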

Compound 4, dissociation constant: 2 nM
Estimate against measurement, compound 4: 1.5-fold (0.19 log units) below; measured number inside the range.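

In this assay, cyclopropyl in place of propyl on an aromatic carbon gives a 1.6-fold higher number from compound 3 to compound 4 (0.20 log units; within the scatter). Going by these compounds alone, the two cores show no difference in this step: the same change on two cores in this assay, a 1.3-fold lower number (0.10 log units; within the scatter) from compound 1 to compound 2 and a 1.6-fold higher number (0.20 log units; within the scatter) from compound 3 to compound 4, 2.0-fold (0.30 log units) apart, within the scatter of two such steps. This shows that the exchange carries over between the core of compound 1 and the core of compound 3 with no step beyond the scatter, but two pairs say nothing about other cores or other assays.

Still open, on these data alone, is how a longer chain, such as butyl, would read at this place on either core. As far as these compounds go, an amine or a carboxylic acid at the same place is equally open, so the tolerance seen covers only propyl and cyclopropyl.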